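Chloro added to the shared core of compound 2

The source may report more compounds than this note shows. Statements on the series, on what has been measured and on what is new or still open speak of the compounds shown alone.

Compound 1 (`O=S(=O)(/C=C/c1ccc(F)cc1F)Cc1ccc(Nc2ncnc3ccccc23)cc1`): > 100000 nM (a limit)
Compound 2 (`O=S(=O)(/C=C/c1ccc(F)cc1Cl)Cc1ccc(Nc2ncnc3ccccc23)cc1`): 21000 nM
Compound 3 (`O=S(=O)(/C=C/c1ccc(C(F)(F)F)cc1F)Cc1ccc(Nc2ncnc3ccccc23)cc1`): 100000 nM

In a functional assay on MCF7 cells (Homo sapiens) (on this read-out lower numbers stand for stronger inhibition of growth and higher numbers for weaker inhibition of growth), compound 2 gives 21000 nM and holds the lowest number of the three. Compound 4 (`O=S(=O)(/C=C/c1ccc(F)cc1Cl)Cc1ccc(Nc2ncnc3cc(Cl)ccc23)cc1`) departs from compound 2 as chloro in place of hydrogen on an aromatic carbon with chloro in place of hydrogen on an aromatic carbon. Going by the values given here, no measured step touches the shared core. Among the compounds with values here, the closest precedent is an at least 4.7-fold lower number from compound 1 to compound 2 (0.67 log units; beyond the scatter) for chloro in place of fluoro on an aromatic carbon, and a 4.8-fold higher number from compound 2 to compound 3 (0.68 log units; beyond the scatter) shows a further step of modest size. On the strength of an at least 4.7-fold lower number from compound 1 to compound 2 (0.67 log units; beyond the scatter) alone, a modest move toward a lower number is expected, with wide uncertainty. The expected step is a 1.8-fold lower number from compound 2 to compound 4 (0.24 log units; within the scatter) on this reasoning. Compound 4 is estimated at 12000 nM within a range from 3000 nM to 50000 nM in this read-out.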

Compound 4, concentration for 50% growth inhibition: 15000 nM
Compound 4: middle estimate off by 1.3-fold (0.10 log units), on the low side; measured number inside the range.
By their numbers in this assay, from the lowest: compounds 4 and 2 (each within the scatter of the next); then compound 3.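

Steps among compound 1, compound 2 and compound 3 left this position untouched; chloro in place of hydrogen on this aromatic carbon, meta to a fused ring and para to a fused ring, gives a 1.4-fold lower number from compound 2 to compound 4 (0.15 log units; within the scatter) in this assay. This position therefore takes chloro without a shift beyond the scatter. Nothing at hand accounts for this step.

Open, going by these compounds, is whether an amine, a methoxy group or a carboxylic acid at this position would shift the number beyond the scatter. Also open, on these data alone, is whether chloro here would act alike alongside the 2-fluoro-4-(trifluoromethyl)phenyl group of compound 3.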